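The source may hold more compounds than are shown below. What is called first, only, known or untested is meant among the compounds shown, and "the series" means these compounds.

Compound 2 `CCc1nnc(SCC(=O)c2ccc(C)cc2)n1N1C(=O)c2ccccc2C1=O` is one of two measured members of a shared core; the other is compound 1 `CCc1nnc(SCc2ccccc2)n1N1C(=O)c2ccccc2C1=O`. In a functional assay on MKN-45 cells (Homo sapiens) for cytotoxicity, read by MTT assay, with a stated time of 48 h (on this read-out higher numbers stand for weaker inhibition and lower numbers for stronger inhibition), compound 2 gives only a limit, > 200000 nM. Compound 1 likewise gives only a limit in this assay, > 200000 nM. The step that the two limits leave unreadable from compound 1 to compound 2 is therefore not readable, and the limit of > 200000 nM in this assay, at which 2 of the 2 values shown sit, is all the measured record shows: both values rest on the same limit, so compound 2 cannot be placed relative to compound 1.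

Compound 3 `CCc1nnc(SC)n1N1C(=O)c2ccccc2C1=O` differs from compound 2 by hydrogen in place of (4-methylphenyl)carbonyl on a saturated chain carbon bound to a sulfur. Going by the values given here, no measured step bears directly on this change; the only measured step, from compound 1 to compound 2, is itself unreadable. Among the compounds with values here, with both measured compounds sitting at the limit, the record gives no direction for the step in this assay, and the expectation is that compound 3 also stays at the limit. The step that the limit leaves unreadable from compound 2 to compound 3 is thus expected to be none that can be read. Compound 3 is estimated at 300000 nM in this assay, with a range from 100000 nM to 1000000 nM, most likely reported only as a limit.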

Compound 3, half-maximal inhibitory concentration: > 200000 nM
Compound 3 gave a limit, no number (the forecaster's own chance of this, stated with the estimate: 90%); the middle value does not contradict the limit.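

Like compound 1 and compound 2, compound 3 gives only a limit in this assay, so none of the steps among these three compounds can be read: the limit of > 200000 nM in this assay, at which 3 of the 3 values shown sit.

The compounds shown leave open whether any group on the saturated chain carbon bound to a sulfur changes the read-out at all, and in which direction.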